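Side-chain trimming in a mitochondrial malate dehydrogenase series

A few compounds are considered here, and "the series" means these few. Any claim that something is new, unique, unknown or untested is made for them only; others in the source may bear on it.

Measured in an assay on isolated protein with malate dehydrogenase, mitochondrial (Sus scrofa) as the target; on this read-out lower numbers stand for stronger inhibition and higher numbers for weaker inhibition:
compound 1 `O=C(O)c1cnc2cc(OCc3c(Cl)c(Cl)c(Cl)c(Cl)c3Cl)ccc2c1O` gives 4790 nM
compound 2 `O=C(O)c1cnc2cc(OCCOc3ccccc3)ccc2c1O` gives 60300 nM
compound 3 `CN(C)c1ccc2c(O)c(C(=O)O)cnc2c1` gives 479000 nM

Compound 2 holds the second highest of the three numbers. Going by the values given here, compound 2 at 60300 nM sits between compound 1 at 4790 nM and compound 3 at 479000 nM, and both gaps lie beyond the scatter, the one to compound 1 being the wider.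

Compound 4 `O=C(O)c1cnc2cc(OCCc3ccccc3)ccc2c1O` differs from compound 2 by one change: phenyl in place of phenoxy on a saturated chain carbon, two bonds along the chain from an oxygen on an aromatic ring. Among the compounds with values here, no measured pair in this set shows this change, so the direction is open; the expected step in this assay is small, at most modest toward a lower number, and may well fall within the scatter. The step from compound 2 to compound 4 is therefore expected to be a 1.5-fold lower number from compound 2 to compound 4 (0.18 log units; within the scatter). For compound 4 the estimated value is 40000 nM, with a range from 10000 nM to 150000 nM.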

Compound 4, half-maximal inhibitory concentration: 38000 nM
For compound 4 the middle estimate is 1.1-fold (0.02 log units) above the measured one; measured number inside the range.
By their numbers in this assay, from the lowest: compound 1; then compounds 4 and 2 (each within the scatter of the next); then compound 3.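

In this assay, going by these compounds alone, phenyl in place of phenoxy on a saturated chain carbon gives a 1.6-fold lower number from compound 2 to compound 4 (0.20 log units; within the scatter), the only step in this set between compounds that differ in one place. At this position, then, the phenoxy oxygen can give way to carbon with no change beyond the scatter. No supporting data bear on this result.

Still open, going by these compounds, is how a longer chain, or an amine in place of the terminal phenyl, would read at this position. On these data alone, a chlorophenyl ring on the same chain is equally open.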